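A few compounds are considered here, and "the series" means these few. Any claim that something is new, unique, unknown or untested is made for them only; others in the source may bear on it.

The series carries a shared core, with compound 1 `N=C(N)c1ccc(-c2ccc(-c3cc(Cl)cc(Cl)c3)s2)cc1` giving 1480 nM in a functional assay on T47D cells (Homo sapiens) for inhibition, read by sulforhodamine B assay, with a stated time of 48 h (on this read-out higher numbers stand for weaker inhibition of growth and lower numbers for stronger inhibition of growth), and compound 3 `N=C(N)c1ccc(-c2ccc(-c3ccccc3)s2)cc1F` giving 5130 nM in this assay. Compound 2 `COc1cc(OC)cc(-c2ccc(-c3ccc(C(=N)N)c(F)c3)s2)c1` gives "not determined" (no result reported) in this assay, so it stands without any number there and gives no anchor of its own. Compound 4 `COc1cc(OC)cc(-c2ccc(-c3ccc(C(=N)N)cc3)s2)c1` is the not yet measured member, and it differs from compound 2 by hydrogen in place of fluoro on an aromatic carbon. Within the data shown here, no pair of measured compounds differs in one place, so the size of this step in this assay cannot be read from a neighbour; nothing here suggests a shift beyond the scatter in either direction. Resting on compound 1 and compound 3 alone, compound 4 is expected at 2500 nM, within 600 nM to 10000 nM.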

Compound 4, concentration for 50% growth inhibition: 1650 nM
Compound 4: middle estimate off by 1.5-fold (0.18 log units), on the high side, and the stated range covers the measured number.
By their numbers in this assay, from the lowest: compounds 1 and 4 (each within the scatter of the next); then compound 3.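

In this assay, among these compounds, compound 2 has no single number, so no step to compound 4 can be read. The compounds shown leave open what hydrogen in place of fluoro does on this aromatic carbon. No evidence bears on the result.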